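Leucine to Glutamine Side Chain on a Purine Glycinamide

A few compounds are considered here, and "the series" means these few. Any claim that something is new, unique, unknown or untested is made for them only; others in the source may bear on it.

Among the measured compounds shown here, compound 2 `CC(C)C[C@H](NC(=O)CN(c1nc(Cl)nc2[nH]cnc12)C1CC1)C(=O)O` is one of two compounds measured in a functional assay on the whole organism (Tail, strain ICR) with Mus musculus as the target, in the tail flick test, with a stated time of 90 min, at a dose of 25 umol/kg by the oral route (a higher number here means a stronger effect of the compound at the dose given, a lower number a weaker effect), and it stands at the lower end of the two numbers: in this assay compound 2 gives 27%, while compound 1 `C[C@@H](O)[C@H](NC(=O)CN(c1nc(Cl)nc2[nH]cnc12)C1CC1)C(=O)O` gives 35.9%. For the measured compounds named here, the only step between them, a number 8.9 percentage points lower from compound 1 to compound 2 (within the scatter), is within the scatter, so the two compounds cannot be ordered on these numbers.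

Compound 3 `NC(=O)CC[C@H](NC(=O)CN(c1nc(Cl)nc2[nH]cnc12)C1CC1)C(=O)O` has not yet been measured in this assay. It differs from compound 2 by carbamoylmethyl in place of isopropyl on a saturated chain carbon, two bonds along the chain from an amide-type nitrogen and a carbonyl carbon. Going by the values given here, the one measured step bears on this change only loosely: in compound 1 a side chain carrying a hydrogen-bond donor and acceptor stood where compound 2 carries isobutyl, and that exchange gave a number 8.9 percentage points lower from compound 1 to compound 2 (within the scatter), within the scatter. Compound 3 again carries a side chain with one hydrogen-bond donor and one acceptor, so the step is expected to be small: a number 5 percentage points higher from compound 2 to compound 3 (within the scatter) is estimated to stay within the scatter. Compound 3 is therefore expected to give about 32% in this assay, with a range from 15% to 50%.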

Compound 3, a percentage reported as activity, at one dose (the size of the read-out at that dose, not a potency): 41.1%
Compound 3: the middle estimate sits 9.1 percentage points below what was measured; low and high end bracket the measured number.
By their numbers in this assay, from the lowest: compounds 2, 1 and 3 (each within the scatter of the next, the first and the last beyond it).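

In this assay, among the compounds shown here, the exchange of isopropyl for carbamoylmethyl on a saturated chain carbon, two bonds along the chain from an amide-type nitrogen and a carbonyl carbon, gives the first step to lie beyond the scatter: a number 14.1 percentage points higher from compound 2 to compound 3 (beyond the scatter). The other new step, a number 5.2 percentage points higher from compound 1 to compound 3 (within the scatter), lies within the scatter, so the 2-carbamoylethyl and 1-hydroxyethyl side chains cannot be ordered, and the 1-hydroxyethyl side chain cannot be separated from either isobutyl or 2-carbamoylethyl; only isobutyl and 2-carbamoylethyl stand apart. Nothing given here accounts for the step from isobutyl to 2-carbamoylethyl.

The compounds shown leave open whether this step belongs to the terminal carbamoyl group or to the length of the chain that carries it, which a carboxylic acid at the end of the same chain, or a carbamoyl group on a shorter chain, would help to separate. They also leave open how a side chain ending in an amine would compare, and, with a single dose and a single time in hand, whether the compounds would show a stronger or weaker effect at any other dose or time.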